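From 2-fluoro-6-methylbenzyl to 3-fluoro-2-methylbenzyl in compound 3

This account rests on a few compounds, and the source may have more. Where it says the series, first, only, none or still open, it means among the compounds named here.

- Compound 1 `Cc1cccc(Cl)c1CN1CCc2cc(-c3c(C)nc(C)c([C@H](OC(C)(C)C)C(=O)O)c3N3CCC(C)(C)CC3)ccc2C1`: 9210 ng.h/mL
- Compound 2 `Cc1cccc(F)c1CN1CCc2cc(-c3c(C)nc(C)c([C@H](OC(C)(C)C)C(=O)O)c3N3CCC(C)(C)CC3)ccc2C1`: 9630 ng.h/mL

Of the compounds shown here, two have been measured in an ADME assay on the whole organism (Rattus norvegicus, strain Sprague-Dawley) for pharmacokinetics, read by LC-MS, at a dose of 5 mg/kg by the oral route; on this read-out higher numbers stand for higher exposure at the dose given and lower numbers for lower exposure. Going by the values given here, the one measured step between them is a 1.0-fold higher number from compound 1 to compound 2 (0.02 log units; within the scatter), with fluoro in place of chloro on an aromatic carbon. Compound 2 therefore stands level with compound 1, within the scatter.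

Compound 3 `Cc1nc(C)c([C@H](OC(C)(C)C)C(=O)O)c(N2CCC(C)(C)CC2)c1-c1ccc2c(c1)CCN(Cc1cccc(F)c1C)C2` has not yet been measured. It has the same atoms as compound 2, joined differently: 3-fluoro-2-methylphenyl in place of 2-fluoro-6-methylphenyl on a saturated chain carbon bound to an amine nitrogen in a ring. Here 3-fluoro-2-methylphenyl takes the place of 2-fluoro-6-methylphenyl on a saturated chain carbon bound to an amine nitrogen in a ring.

Among the compounds with values here, no measured step rearranges a group in this way, so the evidence is indirect. The nearest guide is the exchange on the same group, a 1.0-fold higher number from compound 1 to compound 2 (0.02 log units; within the scatter), which stayed within the scatter. On that single step, no change beyond the scatter is expected in this assay, and the range is kept wide.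

The expected change is a 1.2-fold lower number from compound 2 to compound 3 (0.08 log units; within the scatter).

For compound 3 the estimated value is 8000 ng.h/mL, with an expected range from 3500 ng.h/mL to 18000 ng.h/mL.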

Compound 3, area under the concentration-time curve: 14000 ng.h/mL
For compound 3 the middle estimate is 1.8-fold (0.24 log units) below the measured one, within the range that was stated.
By their numbers in this assay, from the lowest: compounds 1, 2 and 3 (each within the scatter of the next).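

Going by these compounds alone, the exchange of 2-fluoro-6-methylbenzyl for 3-fluoro-2-methylbenzyl is the first rearrangement of this group among the compounds, rather than the swap of a single halogen, and it gives a 1.5-fold higher number from compound 2 to compound 3 (0.16 log units; within the scatter) in this assay, so moving the same atoms around this ring does not carry the read-out beyond the scatter. Set against the chloro compound, the same group gives a 1.5-fold higher number from compound 1 to compound 3 (0.18 log units; within the scatter), which means that none of the three substituted benzyl groups on a saturated chain carbon bound to an amine nitrogen in a ring can be told apart by this read-out, and both the halogen exchange and the rearrangement are tolerated here. Nothing supplied here explains why these three compounds lie so close together.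

The compounds shown leave open whether a different group on this ring, such as a methoxy or a nitrile, would shift the read-out beyond the scatter. They also leave open whether a pyridylmethyl group in place of the substituted benzyl would do so at this same place.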